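Aryl replacement at the imine carbon of the series

This account rests on a few compounds, and the source may have more. Where it says the series, first, only, none or still open, it means among the compounds named here.

Measured so far in a functional assay on SW 1116 cells (Homo sapiens) for cytotoxicity, read by MTT assay, with a stated time of 48 h; a higher number here means a weaker inhibitor, a lower number a stronger inhibitor:
Compound 1, `O=C(CSc1nnc(-c2ccncc2)o1)N/N=C/c1ccc(Cl)cc1`: compound 1 gives 17000 nM
Compound 2, `O=C(CSc1nnc(-c2ccncc2)o1)N/N=C/c1ccc(Br)cc1`: compound 2 gives 21300 nM
Compound 3, `COc1ccc(/C=N/NC(=O)CSc2nnc(-c3ccncc3)o2)cc1`: compound 3 gives 20300 nM

All three numbers sit close together. Compound 3 has the second highest of the three; its nearest neighbour is compound 2, with a 1.0-fold lower number from compound 2 to compound 3 (0.02 log units; within the scatter), and its furthest is compound 1, with a 1.2-fold higher number from compound 1 to compound 3 (0.08 log units; within the scatter). Neither gap is anything more than the scatter, so no order among the three can be read.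

Compound 4, `O=C(CSc1nnc(-c2ccncc2)o1)N/N=C/c1ccccc1[N+](=O)[O-]`, is the next member: 2-nitrophenyl in place of 4-methoxyphenyl on a carbon with a double bond to nitrogen. The measured steps that bear on this are the three exchanges at the aromatic carbon of the same aryl group, a 1.3-fold higher number from compound 1 to compound 2 (0.10 log units; within the scatter), a 1.2-fold higher number from compound 1 to compound 3 (0.08 log units; within the scatter) and a 1.0-fold lower number from compound 2 to compound 3 (0.02 log units; within the scatter), all within the scatter. From the compounds shown here alone, none of them involves a 2-nitrophenyl, so the new group is untested here; the only pattern available is that aryl substituent swaps have left the number essentially unchanged. The step of a 1.0-fold lower number from compound 3 to compound 4 (0.01 log units; within the scatter) is therefore expected to be small, with no direction claimed beyond the scatter. Compound 4 is estimated at 20000 nM, with a range from 8000 nM to 50000 nM.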

Compound 4, half-maximal inhibitory concentration: 30700 nM
Compound 4: middle estimate off by 1.5-fold (0.19 log units), on the low side; the measured number falls inside the stated range.
By their numbers in this assay, from the lowest: compounds 1, 3, 2 and 4 (each within the scatter of the next).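

Notes on the aryl group at the imine carbon: in this assay the exchange of a whole aryl group, with a nitro group in place of the earlier single substituents, still gives only steps within the scatter (a 1.5-fold higher number from compound 3 to compound 4 (0.18 log units; within the scatter)) (a 1.4-fold higher number from compound 2 to compound 4 (0.16 log units; within the scatter)) (a 1.8-fold higher number from compound 1 to compound 4 (0.26 log units; within the scatter)). The last of these is the largest step seen so far in the series, yet it too lies within the scatter, so no order can be read among compound 1, compound 2, compound 3 and compound 4. This position therefore accepts 2-nitrophenyl as well as 4-chlorophenyl, 4-bromophenyl and 4-methoxyphenyl with no readable change in the number, and no measured evidence bears on the reason for this flatness.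

From the compounds shown here alone, whether a 4-aminophenyl, a 4-carboxyphenyl or a saturated cyclohexyl on this carbon would move the number beyond the scatter stays open. Going by these compounds, all four compounds also keep the core of compound 1 unchanged, so the effect of a longer chain in the linker, or of any other change away from this aryl group, is equally open.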